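Swapping methoxycarbonyl for chloro in a growth-inhibition series

This account rests on a few compounds, and the source may have more. Where it says the series, first, only, none or still open, it means among the compounds named here.

Measured in a functional assay on A549 cells (Homo sapiens) for inhibition, read by CCK-8 assay, with a stated time of 72 h, tested at 1 uM; on this read-out lower numbers stand for less inhibition of growth and higher numbers for more inhibition of growth at the one concentration tested
- compound 1 `CN(C)C(=O)c1cc2cnc(Nc3ccc(NC(=O)C4(C(=O)Nc5ccc(F)cc5)CC4)cc3)nc2n1C1CCCC1` gives 86.6%
- compound 2 `Cc1cccc(NC(=O)C2(C(=O)Nc3ccc(Nc4ncc5cc(C(=O)N(C)C)n(C6CCCC6)c5n4)cc3)CC2)c1` gives 35.2%
- compound 3 `COC(=O)c1ccc(NC(=O)C2(C(=O)Nc3ccc(Nc4ncc5cc(C(=O)N(C)C)n(C6CCCC6)c5n4)cc3)CC2)cc1` gives 77.1%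

Two of these numbers sit high together and one sits low, and compound 3 belongs to the high pair. The step of a number 9.5 percentage points lower from compound 1 to compound 3 (within the scatter) lies within the scatter, while the step of a number 41.9 percentage points higher from compound 2 to compound 3 (beyond the scatter) lies beyond it.

The next compound is compound 4 `CN(C)C(=O)c1cc2cnc(Nc3ccc(NC(=O)C4(C(=O)Nc5ccc(Cl)cc5)CC4)cc3)nc2n1C1CCCC1`, and its difference from compound 3 is chloro in place of methoxycarbonyl on an aromatic carbon. In short, chloro takes the place of methoxycarbonyl on an aromatic carbon, para to a large group.

Among the compounds with values here, no measured compound carries chloro, so the closest guide is the step of a number 9.5 percentage points lower from compound 1 to compound 3 (within the scatter), where fluoro and methoxycarbonyl swap at this same place and the number stays within the scatter. The large step of a number 51.4 percentage points lower from compound 1 to compound 2 (beyond the scatter) goes against any simple rule, but it brings in 3-methylphenyl, which compound 4 lacks.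

In this assay the expected change is none beyond the scatter, an estimated a number 4.9 percentage points higher from compound 3 to compound 4 (within the scatter) in size. The estimated value for compound 4 is 82%, with an expected range from 65% to 94%.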

Compound 4, percent growth inhibition at one concentration: 24.7%
Compound 4: middle estimate off by 57.3 percentage points, on the high side; the whole stated range lies above it.
By their numbers in this assay, from the lowest: compound 4; then compound 2; then compounds 3 and 1 (each within the scatter of the next).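

In this assay, putting chloro in place of fluoro on this aromatic carbon, para to a large group, gives a number 61.9 percentage points lower from compound 1 to compound 4 (beyond the scatter), so a change of one halogen atom is enough to shift the result strongly. The swap from methoxycarbonyl to chloro gives a number 52.4 percentage points lower from compound 3 to compound 4 (beyond the scatter), which shows that the closeness of the fluoro and methoxycarbonyl compounds does not extend to every group at this place. The step from 3-methylphenyl to 4-chlorophenyl gives a number 10.5 percentage points lower from compound 2 to compound 4 (beyond the scatter), so a low number here is not tied to the 3-methylphenyl group alone.

Nothing shown here explains why chloro behaves so differently from fluoro. On these data alone, whether bromo, an amine or a carboxylic acid on this carbon would join the high pair or the low pair remains open.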